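Swapping the Sulfonyl for a Hydroxyacetyl Group

The source may report more compounds than this note shows. Statements on the series, on what has been measured and on what is new or still open speak of the compounds shown alone.

The shared core appears in compound 1 `CN1CCN(c2ccc(Nc3ncc4nc(Nc5ccc(F)cc5)n([C@@H]5CCN(C(=O)CO)C5)c4n3)cc2)CC1`, for which a functional assay on A-431 cells (Homo sapiens) for antiproliferative activity, read by MTT assay, with a stated time of 72 h (on this read-out higher numbers stand for weaker inhibition and lower numbers for stronger inhibition), records "not determined" (no result reported), and in compound 3 `CN1CCN(c2ccc(Nc3ncc4nc(Nc5ccc(F)cc5)n([C@H]5CCCNC5)c4n3)cc2)CC1`, for which this assay records "not determined" (no result reported). Compound 2 `CN1CCN(c2ccc(Nc3ncc4nc(Nc5ccc(F)cc5)n([C@H]5CCCN(S(=O)(=O)C6CC6)C5)c4n3)cc2)CC1` holds the only number shown: in this assay compound 2 gives 1340 nM. Compound 4 `CN1CCN(c2ccc(Nc3ncc4nc(Nc5ccc(F)cc5)n([C@H]5CCCN(C(=O)CO)C5)c4n3)cc2)CC1` differs from compound 2 by one change, ((hydroxymethyl)carbonyl in place of cyclopropylsulfonyl on an amine nitrogen in a ring), namely (hydroxymethyl)carbonyl in place of cyclopropylsulfonyl on an amine nitrogen in a ring. Among the compounds with values here, no pair of measured compounds shows a comparable change, so nothing in the data points in either direction. The step from compound 2 to compound 4 is therefore expected to stay within the scatter, a 1.0-fold lower number from compound 2 to compound 4 (0.01 log units; within the scatter). Compound 4 is estimated at 1300 nM, with a range from 400 nM to 4500 nM.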

Compound 4, half-maximal inhibitory concentration: 3000 nM
Compound 4: middle estimate off by 2.3-fold (0.36 log units), on the low side; the range from low to high includes it.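

With (hydroxymethyl)carbonyl in place of cyclopropylsulfonyl on an amine nitrogen in a ring, this assay gives a 2.2-fold higher number from compound 2 to compound 4 (0.35 log units; beyond the scatter), a modest step. Within the data shown here, this is the first readable comparison at this position, and it shows that the number responds to the group on that nitrogen and favours cyclopropylsulfonyl in this pair. Nothing shown accounts for the shift.

From the compounds shown here alone, the step replaces the sulfonyl and the cyclopropyl ring together, so which of them matters stays open. A cyclopropylcarbonyl group or a methylsulfonyl group on that nitrogen would separate the two.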